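Working notes: ethyl to 4-bromobenzyl in the series

This account rests on a few compounds, and the source may have more. Where it says the series, first, only, none or still open, it means among the compounds named here.

Measured in a functional assay on DU-145 cells (Homo sapiens) for antiproliferative activity, read by MTT assay, with a stated time of 48 h; a higher number here means a weaker inhibitor, a lower number a stronger inhibitor:
- Compound 1 `O=C1N(Cc2ccc(Br)cc2)c2ccc(F)cc2C1(O)Cc1nnn[nH]1`: 14400 nM
- Compound 2 `O=C1N(Cc2ccc(Br)cc2)c2ccc(Cl)cc2C1(O)Cc1nnn[nH]1`: 19500 nM
- Compound 3 `CCN1C(=O)C(O)(Cc2nnn[nH]2)c2cc(Br)ccc21`: > 100000 nM (a limit, not a number)

Compound 3 stands at the limit of > 100000 nM in this assay, at which 1 of the 3 values shown sits, and so offers no number to step from. Compound 4 `O=C1N(Cc2ccc(Br)cc2)c2ccc(Br)cc2C1(O)Cc1nnn[nH]1` has yet to be measured in this assay and differs from compound 3 by 4-bromophenyl in place of methyl on a saturated chain carbon bound to an amide-type nitrogen in a ring (4-bromophenyl in place of methyl on a saturated chain carbon bound to an amide-type nitrogen in a ring, or ethyl to 4-bromobenzyl). Within the data shown here, no measured step covers this change directly. The closest evidence is that compound 1 at 14400 nM and compound 2 at 19500 nM both carry the 4-bromobenzyl group and both give numbers. Among the measured compounds shown here, the one measured step is a 1.4-fold higher number from compound 1 to compound 2 (0.13 log units; within the scatter) with chloro in place of fluoro on an aromatic carbon. That step suggests little effect from the halogen on the core, which is bromine in compound 4. A large step toward a stronger inhibitor is therefore expected, estimated as an at least 6.2-fold lower number from compound 3 to compound 4 (0.79 log units; beyond the scatter) in this assay on the lower-number side. The expected value for compound 4 is 16000 nM with an estimated range from 7000 nM to 35000 nM in this assay.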

Compound 4, half-maximal inhibitory concentration: 59600 nM
For compound 4 the middle estimate is 3.7-fold (0.57 log units) below the measured one; the measured number lies above the stated range.
By their numbers in this assay, from the lowest: compounds 1 and 2 (each within the scatter of the next); then compound 4. At a limit, above all of these: compound 3.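

In this assay, the change from ethyl to 4-bromobenzyl on the bromo-bearing core can be read only as a floor, an at least 1.6-fold lower number from compound 3 to compound 4 (0.22 log units; that floor lies within the scatter), so these values do not establish a real gain from this change. The halogen on the core does register among the 4-bromobenzyl compounds, which the fluoro and chloro pair alone did not show: bromo in place of chloro gives a 3.1-fold higher number from compound 2 to compound 4 (0.49 log units; beyond the scatter), and bromo in place of fluoro gives a 4.1-fold higher number from compound 1 to compound 4 (0.62 log units; beyond the scatter). Compound 3 has a limit in place of a number, and the size of the change at this position stays unresolved: the limit of > 100000 nM in this assay, at which 1 of the 4 values shown sits.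

As far as these compounds go, it remains open what an unsubstituted benzyl or a longer chain would give in place of ethyl on the amide-type nitrogen, and whether a 4-chlorobenzyl group would behave as 4-bromobenzyl does. Also open, from the compounds shown here alone, is whether an iodo, methoxy or nitrile group in place of the halogen on the aromatic carbon would extend the rise seen with bromo or break it.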